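The source may hold more compounds than are shown below. What is called first, only, known or untested is meant among the compounds shown, and "the series" means these compounds.

Compound 3 `CCOc1cc(C(Nc2ccc3cnccc3c2)C(=O)NS(=O)(=O)c2ccccc2S(C)(=O)=O)ccc1OC(C)C` is the starting point of this step. In an assay on isolated protein for inhibition of Trypsin (Homo sapiens) (a lower number here means a stronger inhibitor, a higher number a weaker inhibitor), compound 3 gives > 5000 nM, which is a limit of the assay and not a number. Compound 1 `CCOc1cc(C(Nc2ccc3c(N)nccc3c2)C(=O)NS(=O)(=O)c2ccc(O)cc2)ccc1OC(C)C` shares the core with compound 3 but carries a different substituent on the sulfonyl-bearing ring. In this assay compound 1 gives > 5000 nM, again a limit rather than a number. Compound 2 `CCOc1cc(C(Nc2ccc3c(N)nccc3c2)C(=O)NS(=O)(=O)c2ccc(N)cc2)ccc1OC(C)C` differs from compound 1 only by an amino in place of a hydroxy on an aromatic carbon. In this assay compound 2 gives > 5000 nM, which is likewise a limit. Among the compounds with values here, the only change between measured compounds, a step that the two limits leave unreadable from compound 1 to compound 2, therefore cannot be read in size, since (the limit of > 5000 nM in this assay, at which 3 of the 3 values shown sit).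

Compound 4 `CCOc1cc(C(Nc2ccc3cnccc3c2)C(=O)NS(=O)(=O)c2ccccc2S(=O)(=O)CC)ccc1OC(C)C` differs from compound 3 by methyl in place of hydrogen on a saturated chain carbon bound to a sulfonyl sulfur. Within the data shown here, no measured step bears directly on this change, and every measured value sits at the same limit. The step that the limit leaves unreadable from compound 3 to compound 4 from compound 3 to compound 4 is therefore expected to be none beyond the scatter. Compound 4 is estimated to give 8000 nM in this assay, with a range from 3000 nM to 30000 nM, and most likely the assay again reports only a limit.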

Compound 4, inhibition constant: > 5000 nM
Compound 4: no number, only a limit; the forecaster's own chance of this, stated with the estimate: 85%; the middle value lies beyond the limit too.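

Compound 3 and compound 4 both stand at a limit of the assay and not at a number, so no step between them can be read: the limit of > 5000 nM in this assay, at which 4 of the 4 values shown sit.

The compounds shown leave open what number any of them would give in this assay, and so whether the change from methylsulfonyl to ethylsulfonyl makes any difference there.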